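Swapping the aryl group on the side chain of a stilbene inhibitor

This account rests on a few compounds, and the source may have more. Where it says the series, first, only, none or still open, it means among the compounds named here.

Compound 1 `C=CCOc1cc(/C=C\c2cc(OC)c(OC)c(OC)c2)ccc1OC`: 29000 nM
Compound 2 `COc1ccccc1/C=C/CCCOc1cc(/C=C\c2cc(OC)c(OC)c(OC)c2)ccc1OC`: 86000 nM
Compound 3 `COc1cccc(/C=C/CCCOc2cc(/C=C\c3cc(OC)c(OC)c(OC)c3)ccc2OC)c1`: 25000 nM

All three compounds were tested in a functional assay on HT-29 cells (Homo sapiens) for inhibition, read by MTT assay, with a stated time of 3 days; a lower number here means a stronger inhibitor, a higher number a weaker inhibitor. Compound 2 gives the highest number of the three, that is, it is the weakest inhibitor here. Compound 1 stands nearest to it, with a 3.0-fold higher number from compound 1 to compound 2 (0.47 log units; beyond the scatter); compound 3 stands furthest, with a 3.4-fold lower number from compound 2 to compound 3 (0.54 log units; beyond the scatter).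

Compound 4 `COc1ccc(/C=C\c2cc(OC)c(OC)c(OC)c2)cc1OCCC/C=C/c1ccc(Br)cc1` is not yet measured. It differs from compound 2 in one place: 4-bromophenyl in place of 2-methoxyphenyl on a double-bonded chain carbon bound to a double-bonded chain carbon.

Going by the values given here, the step that bears most directly on this change is the one from compound 2 to compound 3, where only the aryl group on the double-bonded chain carbon was altered and the number fell by a modest, but real, amount. The steps from compound 1 show that lengthening the chain itself moved the number little or made it worse, so the aryl group seems to be where the difference is made. A move from 2-methoxyphenyl to 4-bromophenyl is a different change from the one seen, so a similarly modest lowering, or no step beyond the scatter, is expected rather than a large one.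

For compound 4 in this assay the estimate is 30000 nM, within 10000 nM to 90000 nM, which would mean an expected step of a 2.9-fold lower number from compound 2 to compound 4 (0.46 log units; beyond the scatter).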

Compound 4, half-maximal inhibitory concentration: 11000 nM
Compound 4: the middle estimate sits 2.7-fold (0.44 log units) above what was measured, and the stated range covers the measured number.
By their numbers in this assay, from the lowest: compound 4; then compounds 3 and 1 (each within the scatter of the next); then compound 2.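

In this assay, the change from 2-methoxyphenyl to 4-bromophenyl on a double-bonded chain carbon gives a 7.8-fold lower number from compound 2 to compound 4 (0.89 log units; beyond the scatter) and is the largest step seen so far at this position, still modest but clearly larger than the earlier swap between the two methoxyphenyl groups. Going by these compounds alone, the earlier compounds showed only that moving the methoxy group could bring the number back level with that of compound 1, whereas 4-bromophenyl goes further, with a 2.3-fold lower number from compound 3 to compound 4 (0.36 log units; beyond the scatter) against the 3-methoxyphenyl analogue. Against the small end group of the first compound, the full side chain now shows a real gain, a 2.6-fold lower number from compound 1 to compound 4 (0.42 log units; beyond the scatter) being beyond the scatter, so a long aryl-bearing chain at this position need not weaken inhibition, and compound 4 is the strongest inhibitor of the four.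

With a single halogen-bearing ring in the set, the role of the bromine cannot be separated from that of its place on the ring, and 4-chlorophenyl, 4-methoxyphenyl or a longer chain would test this. Nothing measured here offers a reason for these differences.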